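Tetrazole attachment on the benzyloxy phenyl: direct versus methoxy-linked

The source may hold more compounds than are shown below. What is called first, only, known or untested is meant among the compounds shown, and "the series" means these compounds.

Measured compounds:
compound 1 `c1cc(OCc2ccc3ccccc3n2)cc(OCc2ccccc2-c2nn[nH]n2)c1` with 20 nM
compound 2 `c1cc(COc2ccc(OCc3ccc4ccccc4n3)cc2)cc(-c2nn[nH]n2)c1` with 2.2 nM

In an assay on isolated protein for binding affinity to cysteinyl leukotriene receptor 1 (Cavia porcellus) (on this read-out higher numbers stand for weaker inhibition and lower numbers for stronger inhibition), compound 2 gives 2.2 nM and compound 1 gives 20 nM. On these two numbers compound 2 stands lowest; its nearest neighbour is compound 1, a gap beyond the usual scatter. Going by the values given here, both compounds share the quinolinylmethoxy phenyl ether part; they differ in where the tetrazole and the benzyloxy link sit, so no single-site step between them can be read out.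

Compound 3 `c1cc(COc2ccc(OCc3ccc4ccccc4n3)cc2)cc(OCc2nn[nH]n2)c1` departs from compound 2 by (2H-tetrazol-5-yl)methoxy in place of 2H-tetrazol-5-yl on an aromatic carbon. Among the compounds with values here, this is the only change; the rest of the molecule is kept. Within the data shown here, no measured pair isolates this change, so the expectation rests on compound 2 alone. The expected step is a 3.6-fold higher number from compound 2 to compound 3 (0.56 log units; beyond the scatter), a moderate weakening, with the chance that it stays within the scatter. In this assay compound 3 is estimated at 8 nM, with a range from 2 nM to 40 nM.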

Compound 3, inhibition constant: 8 nM
The estimate for compound 3 equals the measured number at the digits printed; measured number inside the range.
By their numbers in this assay, from the lowest: compound 2; then compound 3; then compound 1.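

Going by these compounds alone, the step of a 3.6-fold higher number from compound 2 to compound 3 (0.56 log units; beyond the scatter) in this assay is the first single-site change the series offers, and it is modest though beyond the scatter. At this aromatic carbon, meta to a large group, the tetrazole ring can therefore move out through a methoxy link at a modest cost, with compound 3 still at 8 nM on the same read-out. Nothing available accounts for the size of this step.

Steps from compound 1 to either of the other compounds cannot be read, so the effect of the place of attachment remains apart from this result. Also open, as far as these compounds go, is whether a carboxylic acid in place of the tetrazole ring, or a longer chain such as an ethoxy link to it, would keep the number near those of compound 2 and compound 3.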